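The source may hold more compounds than are shown below. What is called first, only, known or untested is meant among the compounds shown, and "the series" means these compounds.

Measured so far:
- Compound 1 `O=S(=O)(Nc1ccc2oc(-c3ccccc3)nc2c1)c1cccc(F)c1`: in an assay on isolated protein for inhibition of malate dehydrogenase, mitochondrial (Sus scrofa), with stated times of 45 min and 30 min (on this read-out higher numbers stand for weaker inhibition and lower numbers for stronger inhibition), compound 1 gives > 63000 nM, which is a limit of the assay and not a number.
- Compound 2 `O=S(=O)(Nc1ccc(-c2nc3ccccc3o2)cc1)c1ccc(F)cc1`: in this assay compound 2 gives > 63000 nM, again a limit and not a number.

Compound 1 stands at the limit itself; no number places it, and the other value shown sits at the same limit (the limit of > 63000 nM in this assay, at which 2 of the 2 values shown sit). Among the compounds with values here, nothing among the measured compounds separates one from another, and no step between two measured compounds is in hand.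

Compound 3 `Cc1cccc(S(=O)(=O)Nc2ccc3oc(-c4ccccc4)nc3c2)c1` has not yet been measured. It differs from compound 1 by methyl in place of fluoro on an aromatic carbon. The step from compound 1 to compound 3 in this assay is expected to be none beyond the scatter, with the read-out most likely staying at the limit; the estimated step is a step that the limit leaves unreadable from compound 1 to compound 3. Compound 3 is therefore expected to give 100000 nM, within 40000 nM to 300000 nM, most probably reported only as a limit.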

Compound 3, half-maximal inhibitory concentration: > 63000 nM
Compound 3 gave a limit, no number; the forecaster's own chance of this, stated with the estimate: 85%; the middle value is on the limit's open side.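

No step can be read from compound 1 to compound 3, since each result is a limit and not a number: the limit of > 63000 nM in this assay, at which 3 of the 3 values shown sit.

The compounds shown leave open whether any compound in this series gives a measurable inhibition value, and which structural changes would affect it.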